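Trifluoromethyl for trifluoromethoxy in the cyclopentanol series

The source may hold more compounds than are shown below. What is called first, only, known or untested is meant among the compounds shown, and "the series" means these compounds.

Two members of the series have been run in an ADME assay on liver for metabolic stability, with Liver microsome (Homo sapiens) as the target, read by LC-MS, using microsomes, with a stated time of 5 h; a lower number here means slower removal, a higher number faster removal of the compound. Compound 1 `O[C@H](c1ccccn1)[C@]1(c2cccc(OC(F)(F)F)c2)C[C@@H](O)C1` gives 117 mL/min/kg in this assay. Compound 2 `C[C@]1(O)C[C@](c2ccc(OC(F)(F)F)cc2)([C@H](O)c2ccccn2)C1` gives 50 mL/min/kg in this assay, the lower of the two numbers; the gap from compound 1 to compound 2 lies beyond the scatter of repeated runs, so compound 2 stands as the slower-cleared of the pair. Compound 1 and compound 2 differ in more than one place, so no single structural step can be read from them.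

Compound 3 `C[C@]1(O)C[C@](c2ccc(C(F)(F)F)cc2)([C@H](O)c2ccccn2)C1` has not yet been measured. It differs from compound 2 in one place: trifluoromethyl in place of trifluoromethoxy on an aromatic carbon. Within the data shown here, no measured pair shows this change, so its size in this assay is unknown from the data at hand.

Expectation: the step from compound 2 to compound 3 is estimated to be small, within the scatter, as a 1.1-fold lower number from compound 2 to compound 3 (0.05 log units; within the scatter). For compound 3 the estimated value in this assay is 45 mL/min/kg, with a range from 25 mL/min/kg to 85 mL/min/kg; the measured number is awaited.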

Compound 3, clearance: 33.3 mL/min/kg
Beside the measured number, compound 3's estimate is 1.4-fold (0.13 log units) above it; the measured number falls inside the stated range.
By their numbers in this assay, from the lowest: compounds 3 and 2 (each within the scatter of the next); then compound 1.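

In this assay, among these compounds, trifluoromethyl in place of trifluoromethoxy, on an aromatic carbon para to a large group, gives a 1.5-fold lower number from compound 2 to compound 3 (0.18 log units; within the scatter) and is the first single-place step the series offers. Among the compounds shown here, earlier, the only comparison available was between compound 1 and compound 2, which differ in more than one place and so showed nothing about this group on its own. At this position the two fluorinated groups are now seen not to be separated by the read-out, so the oxygen of trifluoromethoxy can go with no change beyond the scatter, and nothing on hand bears on why the step has this size.

The compounds shown leave open how a nitrile, a chlorine atom or a methoxy group at the same place would read in this assay against compound 2 and compound 3. For the compounds shown here, compound 1 still differs from both in more than one place, so no step to it can be read, and whether the same exchange would give a similar step on the core of compound 1 also stays open.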